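The compounds below may be only part of what the source reports. "The series", "measured", "known", "first", "only" and "open" are said of these compounds alone.

Measured so far:
compound 1 `COc1cccc(Cl)c1OCCNCCOc1ccccc1OCc1ccccc1` — 2.51 nM
compound 2 `COc1cccc(C)c1OCCNCCOc1ccccc1OCc1ccccc1` — 2.51 nM

Two compounds of the series have been run in an assay on CHO cells for displacement of a labelled ligand from Alpha-1A adrenergic receptor (Homo sapiens); on this read-out higher numbers stand for weaker inhibition and lower numbers for stronger inhibition. Compound 1 `COc1cccc(Cl)c1OCCNCCOc1ccccc1OCc1ccccc1` gives 2.51 nM in this assay. Compound 2 `COc1cccc(C)c1OCCNCCOc1ccccc1OCc1ccccc1` gives 2.51 nM in this assay, level with compound 1 at the digits shown; the single recorded step, no change at the digits printed from compound 1 to compound 2 (within the scatter), lies within the scatter, so the series has so far produced no movement at all.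

The next compound is compound 3 `Cc1cccc(C)c1OCCNCCOc1ccccc1OCc1ccccc1`. Its difference from compound 2 is methyl in place of methoxy on an aromatic carbon. Among the measured compounds shown here, no measured step swaps methoxy for methyl at this site; the only step available, no change at the digits printed from compound 1 to compound 2 (within the scatter), concerns a different leaving group on the same ring and showed nothing. For the measured compounds named here, that step is the sole guide, and it argues for no movement beyond the scatter, though the change to compound 3 is not the same change and a shift either way cannot be ruled out.

On that basis compound 3 is expected to stay close to compound 2, with the step of a 1.3-fold higher number from compound 2 to compound 3 (0.11 log units; within the scatter) estimated as small. The estimate for compound 3 in this assay is 3.2 nM, with a range from 1 nM to 10 nM.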

Compound 3, inhibition constant: 7.94 nM
Estimate against measurement, compound 3: 2.5-fold (0.39 log units) below; low and high end bracket the measured number.
By their numbers in this assay, from the lowest: compounds 1 and 2 (each within the scatter of the next); then compound 3.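

In this assay, among the compounds shown here, this aromatic carbon is the first place where a change moves the number: methyl in place of methoxy gives a step beyond the scatter (a 3.2-fold higher number from compound 2 to compound 3 (0.50 log units; beyond the scatter)), whereas chloro to methyl on the other substituted carbon gave none (no change at the digits printed from compound 1 to compound 2 (within the scatter)). Replacing the whole 2-chloro-6-methoxyphenyl group with 2,6-dimethylphenyl gives a step of the same printed size (a 3.2-fold higher number from compound 1 to compound 3 (0.50 log units; beyond the scatter)), so across these three compounds all of the movement goes with the loss of methoxy and none with the loss of chloro. Nothing available bears on what lies behind this modest step.

From the compounds shown here alone, it remains open whether a hydroxy, ethoxy or fluoro group on this aromatic carbon would read like the methoxy compounds or like compound 3, which would show whether the step is specific to methoxy. Also open, going by these compounds, is whether removing methoxy costs the same when chloro rather than methyl is the other substituent, and whether the step holds with a group other than benzyloxy on the second aromatic ring.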